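A Methyl Added to a Compound at the Assay Limit

This account rests on a few compounds, and the source may have more. Where it says the series, first, only, none or still open, it means among the compounds named here.

In an ADME assay on MRC5 cells (Homo sapiens) for cytotoxicity, read by fluorescence, with a stated time of 72 h (on this read-out lower numbers stand for stronger inhibition and higher numbers for weaker inhibition), compound 3 (`O=[N+]([O-])c1cn2c(n1)OC(COc1ccc(-c3ccc(C(F)(F)F)cc3)cc1)C2`) gives > 64000 nM, which is a limit of the assay and not a number. Compound 1 (`CC1(COc2ccc(-c3ccc(F)cc3)cc2)Cn2cc([N+](=O)[O-])nc2O1`) gives > 64000 nM, also a limit. Compound 2 (`CC1(COc2ccc(Oc3ccccc3)cc2)Cn2cc([N+](=O)[O-])nc2O1`) gives > 64000 nM, again a limit. Within the data shown here, the whole series so far therefore reads as one line: the limit of > 64000 nM in this assay, at which 3 of the 3 values shown sit.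

Compound 4 (`CC1(COc2ccc(-c3ccc(C(F)(F)F)cc3)cc2)Cn2cc([N+](=O)[O-])nc2O1`) differs from compound 3 by a single change, methyl in place of hydrogen on a saturated ring carbon. Among the measured compounds shown here, no measured step shows this change directly. For the measured compounds named here, the only measured step is a step that the two limits leave unreadable from compound 1 to compound 2, which concerns a different place in the molecule and gives no size to carry over. Compound 1 and compound 2 both carry a methyl on that ring carbon, and neither gives a number in this assay. A step beyond the usual scatter is therefore not expected in this assay, in either direction. The expected change is a number no higher from compound 3 to compound 4 (the limit leaves the size open). For compound 4 the estimate is 64000 nM, with an expected range from 30000 nM to 64000 nM, and the reading will most likely be a limit once more.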

Compound 4, half-maximal inhibitory concentration: > 64000 nM
Compound 4: no number, only a limit; the forecaster's own chance of this, stated with the estimate: 88%; the middle value sits exactly at the limit.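

In this assay compound 4 gives > 64000 nM, a limit and not a number. Among these compounds, no step from compound 1, compound 2 or compound 3 to compound 4 can be read. The compounds shown leave open what size, if any, the methyl change or the other changes have, with every reading at one place: the limit of > 64000 nM in this assay, at which 4 of the 4 values shown sit.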